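Working notes: methoxy step from compound 2 to compound 4

The source may report more compounds than this note shows. Statements on the series, on what has been measured and on what is new or still open speak of the compounds shown alone.

Measured so far in an ADME assay for permeability, using PAMPA; on this read-out higher numbers stand for higher permeability and lower numbers for lower permeability:
- compound 1 `O=C(Nc1ccc([N+](=O)[O-])cc1Cl)c1ccc(Cl)cc1O` reads "not determined" (no result reported)
- compound 2 `O=C(Nc1ccc([N+](=O)[O-])cc1)c1cc(Cl)ccc1O` reads 127 10^-6 cm/s
- compound 3 `O=C(Nc1ccc([N+](=O)[O-])c(Cl)c1)c1cc(Cl)ccc1O` reads 68 10^-6 cm/s

Among the compounds with values here, compound 2 stands within the scatter of compound 3, the only other compound with a number. Compound 4 `COc1cc([N+](=O)[O-])ccc1NC(=O)c1cc(Cl)ccc1O` is still unmeasured. The change from compound 2 is methoxy in place of hydrogen on an aromatic carbon in full, methoxy in place of hydrogen on an aromatic carbon, ortho to a large group and meta to a nitro group. Within the data shown here, the one measured step is a 1.9-fold lower number from compound 2 to compound 3 (0.27 log units; within the scatter) and involves chloro in place of hydrogen, not methoxy, so it is only indirect guidance. No step beyond the scatter is therefore expected in this assay for this change. The expected step is a 1.3-fold lower number from compound 2 to compound 4 (0.13 log units; within the scatter) as estimated here. For compound 4 the estimate is 95 10^-6 cm/s as the expected value, with 40 10^-6 cm/s to 220 10^-6 cm/s as its range.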

Compound 4, apparent permeability: 334 10^-6 cm/s
Estimate against measurement, compound 4: 3.5-fold (0.55 log units) below; measured number outside the range, above it.
By their numbers in this assay, from the lowest: compounds 3 and 2 (each within the scatter of the next); then compound 4.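

In this assay, within the data shown here, methoxy in place of hydrogen on this aromatic carbon, ortho to a large group and meta to a nitro group, gives a 2.6-fold higher number from compound 2 to compound 4 (0.42 log units; beyond the scatter), the first step beyond the scatter. Among these compounds, the only earlier step, a 1.9-fold lower number from compound 2 to compound 3 (0.27 log units; within the scatter), stayed within the scatter and involved chloro, so it gave no sign of such a rise. No measurement bears on what lies behind this step.

From the compounds shown here alone, whether the rise is specific to methoxy stays open. Ethoxy, a longer alkoxy chain or an amine on the same carbon could each read differently.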